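The source may hold more compounds than are shown below. What is called first, only, known or untested is meant among the compounds shown, and "the series" means these compounds.

Of the compounds shown here, two of a shared core have been measured in an assay on isolated protein (strain Sprague-Dawley) for inhibition of Amine oxidase [flavin-containing] A (Rattus norvegicus), read by spectrophotometry, with a stated time of 5 min, tested at 10 uM; on this read-out higher numbers stand for more inhibition at the one concentration tested (going by the name of the read-out) and lower numbers for less inhibition. Compound 1, `CCOc1cc(=O)oc2cc(OCc3cccc(Br)c3)ccc12`, gives 2.5% in this assay. Compound 2, `CNC(=O)COc1cc(=O)oc2cc(OCc3cccc(Cl)c3)ccc12`, gives 11% in this assay. On the numbers shown, compound 2 stands at the top of the two, yet its gap to compound 1 lies within the usual scatter of such measurements, so the two cannot really be told apart: both sit low on the read-out, with only a small part of the enzyme activity held back at the one concentration tested.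

Compound 3, `CC(=O)c1cc(=O)oc2cc(OCc3cccc(Cl)c3)ccc12`, has not yet been measured. It differs from compound 2 in one place: acetyl in place of (methylcarbamoyl)methoxy on an aromatic carbon. Going by the values given here, no measured pair in this set shares that kind of change, so the size of the step cannot be read from neighbours. With both measured numbers low, and nothing to point either way, the step is expected to stay within the scatter, with a slight downward lean at most. The expected step from compound 2 to compound 3 is a number 3 percentage points lower from compound 2 to compound 3 (within the scatter), meaning little real change. For compound 3 in this assay the estimate is 8%, expected to fall between -5% and 25%.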

Compound 3, a percentage reported as inhibition, at one concentration (the size of the read-out at that concentration, not a potency): 0%
For compound 3 the middle estimate is 8 percentage points above the measured one, and the stated range covers the measured number.
By their numbers in this assay, from the lowest: compounds 3, 1 and 2 (each within the scatter of the next, the first and the last beyond it).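

In this assay, replacing (methylcarbamoyl)methoxy with acetyl on the aromatic carbon opposite the ring oxygen gives a number 11 percentage points lower from compound 2 to compound 3 (beyond the scatter). Going by these compounds alone, this is the first readable step in the set, and it shows that the group at this position can shift the read-out, although only modestly and at the low end: compound 2 gives 11% and compound 3 gives 0% at the one concentration tested. The data offer no measured explanation for this step.

The two groups differ at once in size, in the amide with its hydrogen and in the oxygen joining the group to the core, so this single pair cannot show which of these features matters. On these data alone, it also remains open whether a simple amine, a carboxylic acid or a longer chain ending in the same amide at this position would raise inhibition well above the low values seen so far, or would leave it near the bottom of the read-out.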